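Demethylation on the benzothiazole-hydrazone series: a repeat step

The source may report more compounds than this note shows. Statements on the series, on what has been measured and on what is new or still open speak of the compounds shown alone.

Measured so far:
compound 1 `COc1ccc(/C=N/NC(=O)c2ccc(-c3nc4ccccc4s3)cc2)c(O)c1` — 6970 nM
compound 2 `O=C(N/N=C/c1ccc(O)cc1O)c1ccc(-c2nc3ccccc3s2)cc1` — 5580 nM
compound 3 `COc1cccc(/C=N/NC(=O)c2ccc(-c3nc4ccccc4s3)cc2)c1` — 11100 nM

All three were run in an assay on isolated protein for inhibition of Maltase-glucoamylase (Homo sapiens), with a stated time of 15 min; a lower number here means a stronger inhibitor, a higher number a weaker inhibitor. The values of compound 1, compound 2 and compound 3 sit close together: a 1.2-fold lower number from compound 1 to compound 2 (0.10 log units; within the scatter), a 1.6-fold higher number from compound 1 to compound 3 (0.20 log units; within the scatter) and a 2.0-fold higher number from compound 2 to compound 3 (0.30 log units; within the scatter). No ordering among them is claimed.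

Compound 4 `O=C(N/N=C/c1cccc(O)c1)c1ccc(-c2nc3ccccc3s2)cc1` is not yet measured. It differs from compound 3 by hydrogen in place of methyl on an oxygen on an aromatic ring. The same change was already made once, from compound 1 to compound 2, where it reads (hydrogen in place of methyl on an oxygen on an aromatic ring), and there it gave a 1.2-fold lower number from compound 1 to compound 2 (0.10 log units; within the scatter). The two cores on which the change is made differ as 3-methoxyphenyl in place of 2-hydroxy-4-methoxyphenyl on a carbon with a double bond to nitrogen; the place of the change is the same in both pairs.

The expectation for compound 4 rests on that single earlier step: the change from compound 3 to compound 4 is estimated at a 1.2-fold lower number from compound 3 to compound 4 (0.09 log units; within the scatter) in this assay, since the same change gave a 1.2-fold lower number from compound 1 to compound 2 (0.10 log units; within the scatter). Compound 4 is therefore expected near 9000 nM, with a range of 4500 nM to 18000 nM.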

Compound 4, half-maximal inhibitory concentration: 9210 nM
Compound 4: middle estimate off by 1.0-fold (0.01 log units), on the low side, and the stated range covers the measured number.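

In this assay hydrogen in place of methyl on an oxygen on an aromatic ring gives a 1.2-fold lower number from compound 3 to compound 4 (0.08 log units; within the scatter), and the two cores show no difference in this change: the same change on two cores in this assay, a 1.2-fold lower number (0.10 log units; within the scatter) from compound 1 to compound 2 and a 1.2-fold lower number (0.08 log units; within the scatter) from compound 3 to compound 4, 1.0-fold (0.02 log units) apart, within the scatter of two such steps.

Compound 4 also stays close to the other compounds, with a 1.7-fold higher number from compound 2 to compound 4 (0.22 log units; within the scatter) and a 1.3-fold higher number from compound 1 to compound 4 (0.12 log units; within the scatter). The change therefore carries over on these two cores only as a step too small to read: neither step shows a real gain or loss on going from methoxy to hydroxy, and two cores do not establish how it behaves on any other core in the series.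

Still open, going by these compounds, is whether anything other than methyl or hydrogen on that oxygen moves the number beyond the scatter, for example a longer chain or a chain ending in a carboxylic acid or an amine. Also open, on these data alone, is whether any change to the shared core would give a step larger than the scatter.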